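Cyano to trifluoromethyl on the benzyl group

A few compounds are considered here, and "the series" means these few. Any claim that something is new, unique, unknown or untested is made for them only; others in the source may bear on it.

Compound 1 `C=CCOc1ccc2c(=O)c(-c3cc(OC)c(OC)cc3OC)coc2c1`: 5100 nM
Compound 2 `COc1cc(OC)c(-c2coc3cc(OCc4ccc(F)cc4)ccc3c2=O)cc1OC`: 1120 nM
Compound 3 `COc1cc(OC)c(-c2coc3cc(OCc4ccc(C#N)cc4)ccc3c2=O)cc1OC`: 7000 nM

These values come from a functional assay on B16 cells (Mus musculus) for antiproliferative activity, read by MTT assay, with a stated time of 24 h; a lower number here means a stronger inhibitor, a higher number a weaker inhibitor. Compound 3 cannot be told apart from compound 1, as a 1.4-fold higher number from compound 1 to compound 3 (0.14 log units; within the scatter) shows. The clear gap is to compound 2, with a 6.3-fold higher number from compound 2 to compound 3 (0.80 log units; beyond the scatter). Compound 3 therefore sits with compound 1 at the high-number end of this small set, where a higher number means a weaker inhibitor.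

The next compound, compound 4 `COc1cc(OC)c(-c2coc3cc(OCc4ccc(C(F)(F)F)cc4)ccc3c2=O)cc1OC`, has one change: trifluoromethyl in place of cyano on an aromatic carbon. The closest guide is the exchange at that same place, a 6.3-fold higher number from compound 2 to compound 3 (0.80 log units; beyond the scatter), which shows that this one group can matter. The wider step a 4.6-fold lower number from compound 1 to compound 2 (0.66 log units; beyond the scatter) also favours compound 2. Among the compounds with values here, no measured compound carries trifluoromethyl, so a landing point between compound 2 and compound 3 is the cautious expectation. A modest fall in the number is expected in this assay, with an estimated 2.3-fold lower number from compound 3 to compound 4 (0.37 log units; beyond the scatter). For compound 4 the estimated value is 3000 nM, with an expected range from 900 nM to 9000 nM.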

Compound 4, half-maximal inhibitory concentration: 5400 nM
Compound 4: middle estimate off by 1.8-fold (0.26 log units), on the low side; low and high end bracket the measured number.
By their numbers in this assay, from the lowest: compound 2; then compounds 1, 4 and 3 (each within the scatter of the next).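

In this assay, trifluoromethyl and the nitrile cannot be told apart at this place on the benzyl group (a 1.3-fold lower number from compound 3 to compound 4 (0.11 log units; within the scatter)). Fluoro stays separate from trifluoromethyl (a 4.8-fold higher number from compound 2 to compound 4 (0.68 log units; beyond the scatter)), so among the three groups tested on this ring, only fluoro gives a number that stands clear of the others. The trifluoromethyl compound also cannot be separated from the compound with vinyl in place of the substituted phenyl ring (a 1.1-fold higher number from compound 1 to compound 4 (0.02 log units; within the scatter)), so adding this ring does not by itself set a compound apart from compound 1.

Nothing available here explains the gap between fluoro and the other two groups. From the compounds shown here alone, it also remains open whether fluoro is unusual at this place or whether chloro, a methoxy group or an amine would give a similarly low number.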